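Ester bulk on the shared dihydropyridine-type core

The source may hold more compounds than are shown below. What is called first, only, known or untested is meant among the compounds shown, and "the series" means these compounds.

Measured so far:
compound 1, `COC(=O)C1=C(C)NC2=C(C(=O)C(C)(C)CC2)C1c1cc([N+](=O)[O-])ccc1O`, < 30%
compound 2, `CC1=C(C(=O)OCC(C)C)C(c2cc([N+](=O)[O-])cc(Br)c2O)C2=C(CCC(C)(C)C2=O)N1`, 15%
compound 3, `CC1=C(C(=O)OCC(C)C)C(c2cc([N+](=O)[O-])cc(Br)c2O)C2=C(CC(C)(C)CC2=O)N1`, 70%

In an assay for inhibition of Voltage-dependent L-type calcium channel subunit alpha-1C (Rattus norvegicus), read by patch clamp, tested at 10 uM (on this read-out higher numbers stand for more inhibition at the one concentration tested (going by the name of the read-out) and lower numbers for less inhibition), compound 1 gives < 30%, which is a limit of the assay and not a number. Compound 1 thus sits at the limit of < 30% in this assay, at which 1 of the 3 values shown sits, so its own position within the measured set is known only to that extent. Among the measured compounds shown here, compound 2 gives 15% in this assay, and compound 3 gives 70%; these two carry an isobutyl ester and a bromine that compound 1 lacks, and no single-point step connects either of them to compound 1, so their values are noted but not linked to it.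

Compound 4, `CC1=C(C(=O)OC(C)(C)C)C(c2cc([N+](=O)[O-])ccc2O)C2=C(CCC(C)(C)C2=O)N1`, is not yet measured. It differs from compound 1 by tert-butyl in place of methyl on an oxygen next to a carbonyl group. With compound 1 known only as a limit, the step from compound 1 to compound 4 cannot be anchored to a measured step in this assay; the expectation for a step that the limit leaves unreadable from compound 1 to compound 4 is a change not clearly beyond the scatter, if anything slightly upward. Compound 4 is therefore expected to give 25% in this assay, in a range from 5% to 55%.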

Compound 4, a percentage reported as inhibition, at one concentration (the size of the read-out at that concentration, not a potency): < 30%
Compound 4: only a limit was reported (the forecaster's own chance of this, stated with the estimate: 45%); the middle value is on the limit's open side.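

With compound 1 and compound 4 both reported only as limits in this assay, no step can be read between them: the limit of < 30% in this assay, at which 2 of the 4 values shown sit.

Going by these compounds, whether tert-butyl in place of methyl on an oxygen next to a carbonyl group changes inhibition at all remains open, as does where either compound truly lies.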